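Swapping a naphthalene for a carbamoylbenzyl group

A few compounds are considered here, and "the series" means these few. Any claim that something is new, unique, unknown or untested is made for them only; others in the source may bear on it.

Compound 2 `Nc1ncnc2c1ncn2[C@@H]1O[C@H](CN(CCCc2ccc3ccccc3c2)CC[C@H](N)C(=O)O)[C@@H](O)[C@H]1O` gives 4000 nM in an assay on cells for inhibition of Nicotinamide N-methyltransferase (Homo sapiens), read by fluorescence and coupled enzyme assay, with a stated time of 10 min, in the presence of a further agent that is not named here (on this read-out lower numbers stand for stronger inhibition and higher numbers for weaker inhibition), the lowest of the two numbers; compound 1 `Nc1ncnc2c1ncn2[C@@H]1O[C@H](CN(CCCc2cccc3ccccc23)CC[C@H](N)C(=O)O)[C@@H](O)[C@H]1O` gives 11800 nM. Among the compounds with values here, the only step so far, a 3.0-fold lower number from compound 1 to compound 2 (0.47 log units; beyond the scatter), moved one ring attachment point. Compound 3 `NC(=O)c1cccc(CCCCN(CC[C@H](N)C(=O)O)C[C@H]2O[C@@H](n3cnc4c(N)ncnc43)[C@H](O)[C@@H]2O)c1` makes a different change: 3-carbamoylbenzyl in place of naphthalen-2-yl on a saturated chain carbon, three bonds along the chain from an amine nitrogen. Within the data shown here, no step bears directly on this change, so the expected size and direction are uncertain; compound 3 is estimated to show a 2.7-fold lower number from compound 2 to compound 3 (0.43 log units; beyond the scatter), with a broad range. Compound 3 is expected at 1500 nM, from 100 nM to 20000 nM.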

Compound 3, inhibition constant: 840 nM
The estimate for compound 3 lay 1.8-fold (0.25 log units) above the measured number, and the stated range covers the measured number.
By their numbers in this assay, from the lowest: compound 3; then compound 2; then compound 1.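

In this assay, the position on a saturated chain carbon, three bonds along the chain from an amine nitrogen, does not depend on a naphthalene: 3-carbamoylbenzyl gives a 4.8-fold lower number from compound 2 to compound 3 (0.68 log units; beyond the scatter) and a 14-fold lower number from compound 1 to compound 3 (1.15 log units; beyond the scatter). The entering group has one six-membered aromatic ring instead of two and adds a hydrogen-bond donor and acceptor, yet it gives the lowest number of the three compounds. Nothing measured explains this difference. As far as these compounds go, it remains open whether the carbamoyl group or the loss of the second ring matters more; a plain benzyl group, or a carboxylic acid in place of the carbamoyl group, would help separate the two.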